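Working notes on a methyl-to-methoxy step

A few compounds are considered here, and "the series" means these few. Any claim that something is new, unique, unknown or untested is made for them only; others in the source may bear on it.

Measured compounds:
Compound 1, `Cc1ccc(/C=C2\CCC/C(=C\c3cccc([N+](=O)[O-])c3)C2=O)cc1`: in a functional assay on HSC-4 cells (Homo sapiens) for cytotoxicity, with a stated time of 24 h (a higher number here means that more compound is tolerated, a lower number that less compound is tolerated), compound 1 gives 45000 nM.
Compound 2, `COc1ccc(/C=C2\CCC/C(=C\c3cccc([N+](=O)[O-])c3)C2=O)cc1`: in this assay compound 2 gives 11000 nM.
Compound 3, `Cc1ccc(/C=C2\CCC/C(=C\c3ccc([N+](=O)[O-])cc3)C2=O)cc1`: in this assay compound 3 gives 13000 nM.

Compound 2 differs from compound 1 by methoxy in place of methyl on an aromatic carbon. That single change produced a 4.1-fold lower number from compound 1 to compound 2 (0.61 log units; beyond the scatter). Compound 3 keeps the methyl-bearing side of compound 1 but sits on a different core; the difference between the two cores is not broken down here. In this assay compound 3 lies within the scatter of compound 2 and beyond the scatter from compound 1.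

Compound 4, `COc1ccc(/C=C2\CCC/C(=C\c3ccc([N+](=O)[O-])cc3)C2=O)cc1`, is not yet measured. It differs from compound 3 by methoxy in place of methyl on an aromatic carbon, and the place of the change reads the same as between compound 1 and compound 2, so this is the same change carried onto the second core. For the measured compounds named here, only one earlier instance of it exists, on one core, so how far it transfers is open. Because that instance gave a 4.1-fold lower number from compound 1 to compound 2 (0.61 log units; beyond the scatter), compound 4 is expected to show a step of about a 2.9-fold lower number from compound 3 to compound 4 (0.46 log units; beyond the scatter), kept somewhat smaller than the precedent. Compound 4 is expected to come in near 4500 nM, within a range of 2000 nM to 11000 nM.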

Compound 4, half-maximal cytotoxic concentration: > 400000 nM
Compound 4 ended at the assay's limit; the forecaster's own chance of this, stated with the estimate: 5%; middle value at least 88-fold (1.94 log units) from the limit.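

In this assay, the change from 4-methylphenyl to 4-methoxyphenyl gave an at least 30-fold higher number from compound 3 to compound 4 (1.48 log units; beyond the scatter), so neither the direction nor the size of the earlier step carried over to the second core: the same change on two cores in this assay, a 4.1-fold lower number (0.61 log units; beyond the scatter) from compound 1 to compound 2 and an at least 30-fold higher number (1.48 log units; beyond the scatter) from compound 3 to compound 4, at least 120-fold (2.09 log units) apart, beyond the scatter of two such steps

Compound 4 gives > 400000 nM, which is a limit of the assay and not a number.

Within these four compounds, the outcome of this change therefore differs with the core, but two matched pairs give no general rule for the series and do not show which feature of the core, or what mechanism, lies behind the reversal.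

Still open, as far as these compounds go, is whether either direction recurs on further cores, or whether one of the two pairs is the exception. Also open, from the compounds shown here alone, is how other groups on the same aromatic carbon would behave on these two cores, such as an amine, a carboxylic acid or a longer alkoxy chain like ethoxy.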